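The source may report more compounds than this note shows. Statements on the series, on what has been measured and on what is new or still open speak of the compounds shown alone.

Measured compounds:
compound 1, `O=C(N1CCCCC1)N1CC(c2nc(-c3cccc(Cl)c3)no2)C1`, gives 370 nM in an assay on HEK293 cells for positive allosteric modulation of metabotropic glutamate receptor 5 (Homo sapiens), read by FLIPR; on this read-out lower numbers stand for an effect already at smaller amounts and higher numbers for an effect only at larger amounts of compound.
compound 2, `O=S(=O)(c1ccc(F)cc1)N1CC(c2nc(-c3cccc(Cl)c3)no2)C1`, reaches only the limit of > 10000 nM in this assay, not a number.

Within the data shown here, compound 1 therefore holds the only number in this assay; the one other value is a limit. For compound 2 the value sits at the limit of > 10000 nM in this assay, at which 1 of the 2 values shown sits, so the two compounds cannot be set against each other by size.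

The step now followed leads from compound 1 to compound 3, `COC1CCN(C(=O)N2CC(c3nc(-c4cccc(Cl)c4)no3)C2)CC1`. The change is methoxy in place of hydrogen on a saturated ring carbon. Among the measured compounds shown here, no measured pair shows a step of this kind, so no size can be read from the numbers. Compound 3 is expected to sit close to compound 1, with a step of a 1.4-fold higher number from compound 1 to compound 3 (0.13 log units; within the scatter) that is not expected to go beyond the scatter in either direction. For compound 3 the estimate in this assay is 500 nM, within 150 nM to 2000 nM.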

Compound 3, half-maximal effective concentration: > 10000 nM
Compound 3: no number, only a limit; the forecaster's own chance of this, stated with the estimate: 10%; middle value at least 20-fold (1.30 log units) from the limit.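

Compound 3 reaches only a limit, not a number. In this assay, the change from piperidin-1-yl to 4-methoxypiperidin-1-yl amounts to an at least 27-fold higher number from compound 1 to compound 3 (1.43 log units; beyond the scatter), so a methoxy on this saturated ring carbon, three ring bonds from the ring nitrogen, is enough to take the value out of the measurable range. Among these compounds, compound 3 thus joins compound 2, and compound 1 remains the only compound with a number: the limit of > 10000 nM in this assay, at which 2 of the 3 values shown sit.

The compounds shown leave open whether this loss belongs to methoxy itself or to any group on this ring carbon, which a fluorine, a hydroxyl or a methyl there could separate. They also leave open how far the loss reaches along the ring, since a methoxy on another ring carbon of the piperidine does not appear among them.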